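The source may report more compounds than this note shows. Statements on the series, on what has been measured and on what is new or still open speak of the compounds shown alone.

Of the compounds shown here, two have been measured in a functional assay on PC-3 cells (Homo sapiens) for antiproliferative activity, read by WST assay, with a stated time of 3 days; on this read-out lower numbers stand for stronger inhibition and higher numbers for weaker inhibition. Compound 1 `C/C1=C/C=C/C(=O)N[C@@H](C=O)C/C(C)=C/COCC/C=C/C(=O)C1` carries a formyl group on a saturated ring carbon, and in this assay compound 1 gives 9760 nM. Compound 2 `COc1ccc(COC[C@H]2C/C(C)=C/COCC/C=C/C(=O)C/C(C)=C\C=C\C(=O)N2)cc1` carries a ((4-methoxybenzyl)oxy)methyl group on that ring carbon instead, and in this assay compound 2 gives 7700 nM. The step of a 1.3-fold lower number from compound 1 to compound 2 (0.10 log units; within the scatter) lies within the scatter, so these two numbers cannot be told apart and neither compound can be called stronger.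

Compound 3 `C/C1=C/C=C/C(=O)N[C@@H](CO)C/C(C)=C/COCC/C=C/C(=O)C1` has not yet been measured. It differs from compound 2 by hydrogen in place of 4-methoxybenzyl on an oxygen on a saturated carbon, so that a hydroxymethyl group remains. Within the data shown here, the only measured step touching this part of the structure is a 1.3-fold lower number from compound 1 to compound 2 (0.10 log units; within the scatter), which stayed within the scatter, and no step beyond the scatter is therefore expected in this assay. Compound 3 is expected to show a step of a 1.0-fold higher number from compound 2 to compound 3 (0.02 log units; within the scatter). Compound 3 is estimated at 8000 nM, within a range from 3000 nM to 25000 nM.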

Compound 3, half-maximal inhibitory concentration: > 12500 nM
Compound 3 was reported as a limit; the forecaster's own chance of this, stated with the estimate: 10%; at least 1.5-fold (0.19 log units) between middle value and limit.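

Compound 3 carries a free hydroxy where compound 2 carries the (4-methoxybenzyl)oxy group. In this assay compound 3 is reported as a limit and not as a number (> 12500 nM): the limit of > 12500 nM in this assay, at which 1 of the 3 values shown sits. Removing the 4-methoxybenzyl group therefore gives only a floor (an at least 1.6-fold higher number from compound 2 to compound 3 (0.21 log units; that floor lies within the scatter)), and so does hydroxymethyl in place of formyl (an at least 1.2-fold higher number from compound 1 to compound 3 (0.10 log units; that floor lies within the scatter)). This ring carbon has now carried three groups, one of them with a six-membered aromatic ring, and no step among them is shown to lie beyond the scatter, so the 4-methoxybenzyl group is shown neither to be needed nor to be dispensable.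

As far as these compounds go, how far the true value of compound 3 lies past its limit remains open. So does the reading of an amine or a carboxylic acid on this ring carbon, or of a longer chain on the oxygen.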